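A few compounds are considered here, and "the series" means these few. Any claim that something is new, unique, unknown or untested is made for them only; others in the source may bear on it.

In a functional assay on MDA-MB-231 cells (Homo sapiens) for cytotoxicity, read by WST assay, with a stated time of 48 h (on this read-out lower numbers stand for stronger inhibition and higher numbers for weaker inhibition), compound 2 `O=C(NC(=S)Nc1cccc(-c2nc3ccccc3[nH]2)c1)c1ccc2c(c1)OCCO2` gives 400 nM, the lowest of the two numbers at hand. Compound 3 `Cc1ccc(-c2nc3ccccc3[nH]2)cc1NC(=S)NC(=O)c1ccc2c(c1)OCCO2` gives 530 nM, and the step of a 1.3-fold higher number from compound 2 to compound 3 (0.12 log units; within the scatter) stays within the scatter. Compound 1 `N#Cc1ccc2[nH]c(-c3cccc(NC(=S)NC(=O)c4ccc5c(c4)OCCO5)c3)nc2c1` reaches only the limit of > 10000 nM, which is a limit of this assay and not a number. The step of an at least 25-fold lower number from compound 1 to compound 2 (1.39 log units; beyond the scatter) is therefore a floor set by the limit of > 10000 nM in this assay, at which 1 of the 3 values shown sits.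

Compound 4 `O=C(NC(=S)Nc1cccc(-c2nc3ccccc3s2)c1)c1ccc2c(c1)OCCO2` differs from compound 2 by 1,3-benzothiazol-2-yl in place of 1H-benzimidazol-2-yl on an aromatic carbon. Neither measured step exchanges this ring system: the step from compound 1 to compound 2 alters a substituent on the group that leaves, the step from compound 2 to compound 3 alters the phenyl ring. The large first step shows this assay responds strongly to changes in that part of the molecule, the second shows small changes elsewhere pass unnoticed. For compound 4 in this assay a modest rise in the number, a 2.0-fold higher number from compound 2 to compound 4 (0.30 log units; within the scatter), is expected, with wide uncertainty. Compound 4 is estimated at 800 nM, between 200 nM and 4000 nM.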

Compound 4, half-maximal inhibitory concentration: > 10000 nM
Compound 4 ended at the assay's limit; the forecaster's own chance of this, stated with the estimate: 10%; middle value at least 12-fold (1.09 log units) away from the limit.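

Exchanging 1H-benzimidazol-2-yl for 1,3-benzothiazol-2-yl on an aromatic carbon, meta to a large group, gives an at least 25-fold higher number from compound 2 to compound 4 (1.39 log units; beyond the scatter) in this assay, so this position responds to the identity of the ring itself and not only to a substituent on it. The two groups have the same ring types and the same heavy-atom total, and they differ in their hetero atoms and in their hydrogen-bond donor and acceptor counts, which this single exchange does not separate. The step between compound 1 and compound 4 cannot be read, as both stand at a limit, and no order can be given between them: the limit of > 10000 nM in this assay, at which 2 of the 4 values shown sit.

Which of those differences carries the step remains open. The response to a 1,3-benzoxazol-2-yl group at this place, or to methyl on a ring nitrogen of the 1H-benzimidazol-2-yl group, is also unknown from the compounds shown.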